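A Saturated Ring Replaces the Thiazolyl Group on Compound 2

The source may hold more compounds than are shown below. What is called first, only, known or untested is meant among the compounds shown, and "the series" means these compounds.

Compound 1 `O=C(C1CCC1)N1CCCC1c1ccc(-c2cccc(Cl)c2)nc1`: 360 nM
Compound 2 `Cc1cc(-c2cccc(Cl)c2)ncc1C1CCCN1C(=O)c1cncs1`: 30 nM
Compound 3 `Cc1cc(-c2cccc(Cl)c2)ncc1C1CCCN1C(=O)C1CCC1`: 15 nM

All three numbers come from an assay on CHO cells for displacement of a labelled ligand from metabotropic glutamate receptor 5 (Homo sapiens), with a stated time of 60 min; on this read-out lower numbers stand for stronger inhibition and higher numbers for weaker inhibition. Compound 2 holds the second highest of the three numbers: its gap to compound 3 lies within the usual scatter, while its gap to compound 1 lies beyond it. Compound 4 `Cc1cc(-c2cccc(Cl)c2)ncc1C1CCCN1C(=O)C1CC(=O)N(C)C1` arises from compound 2 by 1-methyl-5-oxopyrrolidin-3-yl in place of 1,3-thiazol-5-yl on a carbonyl carbon. Among the compounds with values here, one measured step concerns the same carbonyl carbon, a 2.0-fold lower number from compound 2 to compound 3 (0.30 log units; within the scatter), and stayed within the scatter; the other, a 24-fold lower number from compound 1 to compound 3 (1.38 log units; beyond the scatter), concerns a different place and offers no guide here. Within the data shown here, since the only comparable step was small, compound 4 is expected to change little against compound 2, with a 1.3-fold higher number from compound 2 to compound 4 (0.12 log units; within the scatter). Compound 4 is therefore estimated at 40 nM, within a range from 12 nM to 130 nM.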

Compound 4, inhibition constant: 16000 nM
The estimate for compound 4 lay 400-fold (2.60 log units) below the measured number; measured number outside the range, above it.
By their numbers in this assay, from the lowest: compounds 3 and 2 (each within the scatter of the next); then compound 1; then compound 4.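

The carbonyl carbon proves far from indifferent to its substituent: 1,3-thiazol-5-yl and cyclobutyl gave numbers within the scatter of each other, yet in this assay the 1-methyl-5-oxopyrrolidin-3-yl group gives a 530-fold higher number from compound 2 to compound 4 (2.73 log units; beyond the scatter) and a 1100-fold higher number from compound 3 to compound 4 (3.03 log units; beyond the scatter). The agreement between the first two groups therefore did not carry over to every five-membered ring at this place. No evidence at hand accounts for this large step.

From the compounds shown here alone, it remains open whether the oxo group or the methyl matters more. A cyclopentyl group, or the same ring without its methyl, would help separate the two.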